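The compounds below may be only part of what the source reports. "The series", "measured", "known", "first", "only" and "open" are said of these compounds alone.

Compound 3 `CC1(C)SC(c2cc(Cl)ccc2N)=NN1C(=O)C1CCCCC1` carries a cyclohexyl on the carbonyl carbon of a shared core and, in an assay on isolated protein for inhibition of Nitric oxide synthase, inducible (Homo sapiens), read by scintillation counting, with a stated time of 30 min, tested at 50 uM (on this read-out lower numbers stand for less inhibition and higher numbers for more inhibition at the one concentration tested (going by the name of the read-out)), compound 3 gives 7.61%. That is the lowest of the three numbers measured. Its nearest neighbour is compound 1 `CC1(C)SC(c2ccccc2N)=NN1C(=O)c1ccccc1`, which in this assay gives 39.8%; its most distant is compound 2 `CCCC(=O)N1N=C(c2cc(Cl)ccc2N)SC1(C)C`, which gives 66.2%. Among the compounds with values here, only one single-point step is available: the change from propyl to cyclohexyl on the carbonyl carbon, a number 58.6 percentage points lower from compound 2 to compound 3 (beyond the scatter), a large fall well beyond the scatter.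

Compound 4 `CC1(C)SC(c2cc(Cl)ccc2N)=NN1C(=O)c1ccccc1` differs from compound 3 by phenyl in place of cyclohexyl on a carbonyl carbon. Within the data shown here, no measured step covers phenyl against cyclohexyl directly. Compound 1 also carries a phenyl on the carbonyl carbon, though it lacks the chloro substituent, and its number sits well above that of compound 3. Because a number 58.6 percentage points lower from compound 2 to compound 3 (beyond the scatter) shows the number with the cyclohexyl on the carbonyl carbon to be the lowest seen, a rise is expected on replacing it, estimated as a number 34.4 percentage points higher from compound 3 to compound 4 (beyond the scatter). Compound 4 is therefore expected to give about 42%, within the range 15% to 68%.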

Compound 4, a percentage reported as inhibition, at one concentration (the size of the read-out at that concentration, not a potency): 20.8%
Compound 4: the middle estimate sits 21.2 percentage points above what was measured, and the stated range covers the measured number.
By their numbers in this assay, from the lowest: compound 3; then compound 4; then compound 1; then compound 2.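

On the carbonyl carbon, phenyl in place of cyclohexyl gives a number 13.2 percentage points higher from compound 3 to compound 4 (beyond the scatter) in this assay so the aromatic ring recovers only a small part of what the non-aromatic ring lost. Phenyl in place of propyl gives a number 45.4 percentage points lower from compound 2 to compound 4 (beyond the scatter) and so both groups with a six-membered ring sit far under the propyl compound. Within the data shown here, the first view of a change on the aromatic carbon comes from chloro in place of hydrogen, which gives a number 19 percentage points lower from compound 1 to compound 4 (beyond the scatter) with phenyl held on the carbonyl carbon, so chloro lowers the number in this pair.

From the compounds shown here alone, whether a longer chain or a carboxylic acid on the carbonyl carbon would match propyl stays open, as does whether chloro lowers the number with groups other than phenyl there. Nothing available explains why these groups differ in this way.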